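Bromo to Nitro on the Shared Core

The source may hold more compounds than are shown below. What is called first, only, known or untested is meant among the compounds shown, and "the series" means these compounds.

Of the compounds shown here, three built on one shared core have been tested in a functional assay on K562 cells (Homo sapiens) for antiproliferative activity, read by MTT assay, with a stated time of 24 h; a lower number here means a stronger inhibitor, a higher number a weaker inhibitor. Compound 1 `COc1ccc(C(=O)/C=C/c2cc(OC)c(OC)c(OC)c2)c2c1C=CC(C)(C)O2` reaches only a limit of the assay rather than a number there, > 10000 nM. Compound 2 `COc1cc(OC)c(OC)cc1/C=C/C(=O)c1ccc(OC)c2c1OC(C)(C)C=C2` likewise stops at the limit, with > 10000 nM. Compound 3 `COc1ccc(C(=O)/C=C/c2ccc(Br)cc2)c2c1C=CC(C)(C)O2` also gives nothing more than the limit, > 10000 nM. Compound 3 therefore stands nowhere in particular among the three: every value shown sits at the same limit, a situation summed up as the limit of > 10000 nM in this assay, at which 3 of the 3 values shown sit, and no order among the compounds can be read from it.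

Going by the values given here, no step between measured compounds exists here; a single unmeasured compound follows. Compound 4 `COc1ccc(C(=O)/C=C/c2ccc([N+](=O)[O-])cc2)c2c1C=CC(C)(C)O2` differs from compound 3 by nitro in place of bromo on an aromatic carbon. With all three measured values resting at the limit, nothing shows whether a change of this kind moves the number up or down. A step that the limit leaves unreadable from compound 3 to compound 4 is expected, which amounts to none beyond the scatter. Compound 4 is accordingly expected to come out near 15000 nM in this assay, within a range from 4000 nM to 60000 nM, and quite possibly as another limit rather than a number.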

Compound 4, half-maximal inhibitory concentration: 7770 nM
The estimate for compound 4 lay 1.9-fold (0.29 log units) above the measured number; the measured number falls inside the stated range.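

In this assay compound 4 gives 7770 nM, the only actual number among the four compounds shown, so this place on the aromatic ring, para to a large group, can carry a group that brings the value within the measurable range. For compound 3 the value > 10000 nM is a limit of the assay and not a number. Going from 4-bromophenyl to 4-nitrophenyl gives an at least 1.2-fold lower number from compound 3 to compound 4 (0.10 log units; that floor lies within the scatter), so the change is established only as a floor that does not clear the scatter, and its true size cannot be read because the starting value is one of the limits: the limit of > 10000 nM in this assay, at which 3 of the 4 values shown sit.

From the compounds shown here alone, whether other groups at this same place, such as an amine or a carboxylic acid, would also give a number in this assay remains open, and so does whether any of them would go lower than compound 4. With a single number on the shared core, the compounds shown also leave open whether nitro itself matters or whether a different group in the same place would do as well.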